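Ret V804M series: fluoro added on the central ring

This account rests on a few compounds, and the source may have more. Where it says the series, first, only, none or still open, it means among the compounds named here.

The series shares one core and a urea whose far end varies. Compound 1 `COc1ccc(NC(=O)Nc2ccc(Nc3ncnc4c3OCCN4)cc2)cc1` gives 824 nM in an assay on isolated protein for inhibition of proto-oncogene tyrosine-protein kinase receptor Ret variant V804M (Homo sapiens), read by 33P incorporation, with stated times of 15 min and 40 min; a lower number here means a stronger inhibitor, a higher number a weaker inhibitor. Compound 2 `COc1cccc(NC(=O)Nc2ccc(Nc3ncnc4c3OCCN4)cc2)c1` gives 5290 nM in this assay, and the step of a 6.4-fold higher number from compound 1 to compound 2 (0.81 log units; beyond the scatter) separates the two. Compound 3 `CC(C)(C)c1cc(NC(=O)Nc2ccc(Nc3ncnc4c3OCCN4)cc2)no1` gives 34 nM in this assay, the lowest of the three numbers; the steps of a 24-fold lower number from compound 1 to compound 3 (1.38 log units; beyond the scatter) and a 160-fold lower number from compound 2 to compound 3 (2.19 log units; beyond the scatter) set it well apart from both.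

Compound 4 `CC(C)(C)c1cc(NC(=O)Nc2ccc(Nc3ncnc4c3OCCN4)c(F)c2)no1` is not yet measured. It differs from compound 3 in one place: fluoro in place of hydrogen on an aromatic carbon. None of the three measured steps touches this position; each of them swaps the whole group on the amide-type nitrogen at the far end of the urea, and those swaps ranged from modest to large. For the measured compounds named here, no step in the set exchanges a hydrogen for a fluoro, so nothing measured bears directly on this change, and the expectation is a step of no clear size beyond the scatter, in either direction. For compound 4 the expected step is a 1.1-fold lower number from compound 3 to compound 4 (0.05 log units; within the scatter). Compound 4 is therefore estimated at 30 nM in this assay, with a range from 10 nM to 100 nM.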

Compound 4, half-maximal inhibitory concentration: 22 nM
The estimate for compound 4 lay 1.4-fold (0.13 log units) above the measured number; low and high end bracket the measured number.
By their numbers in this assay, from the lowest: compounds 4 and 3 (each within the scatter of the next); then compound 1; then compound 2.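

Fluoro in place of hydrogen on this aromatic carbon, ortho to a large group and meta to a large group, gives a 1.5-fold lower number from compound 3 to compound 4 (0.19 log units; within the scatter) in this assay, so compound 3 and compound 4 cannot be told apart in this assay. For the compounds shown here, this is the first reading on the ring itself, as the earlier steps all swapped the group at the far end of the urea, and it shows that this position accepts a fluoro with the 5-(tert-butyl)-1,2-oxazol-3-yl group in place, with no measurable gain or loss. No supporting measurement bears on why the number holds at this position.

From the compounds shown here alone, whether chloro, methyl or methoxy on the same carbon would stay as close to compound 3 remains open. Also open, going by these compounds, is whether fluoro here gives a step of similar size when 4-methoxyphenyl or 3-methoxyphenyl sits at the far end of the urea.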